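This account rests on a few compounds, and the source may have more. Where it says the series, first, only, none or still open, it means among the compounds named here.

Within this small series the compounds share one core and differ at a single aromatic carbon. Compound 1 `O=C1CCCN1c1cnc(NCc2c(F)ccc3c2CCO3)n2cnnc12` gives 1.3 in a physicochemical assay for lipophilicity, using the shake flask method, in phosphate buffer, measured as octanol-water partition, with a stated time of 30 min, at pH 7.4; a higher number here means a more lipophilic compound, a lower number a more polar compound. Compound 2 `CC1(C)CC(=O)N(c2cnc(NCc3c(F)ccc4c3CCO4)n3cnnc23)C1` gives 2 in this assay, with the step of a number 0.70 log units higher from compound 1 to compound 2 (beyond the scatter). Compound 3 `O=C(Nc1cnc(NCc2c(F)ccc3c2CCO3)n2cnnc12)c1cccnc1` gives 2 in this assay; the step of a number 0.70 log units higher from compound 1 to compound 3 (beyond the scatter) matches it in size, and no change at the digits printed from compound 2 to compound 3 (within the scatter). Compound 3 thus stands level with compound 2, and the two of them sit together above compound 1 as the highest of the three numbers.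

Compound 4 `Fc1ccc2c(c1CNc1ncc(Nc3ccccc3)c3nncn13)CCO2` has not yet been measured in this assay. It differs from compound 3 by phenyl in place of (pyridin-3-yl)carbonyl on a nitrogen on an aromatic ring. For the measured compounds named here, none of the three measured steps removes a carbonyl or a ring nitrogen at this position, so none bears on the change directly; they show only that exchanging the group on that aromatic carbon has moved this assay by modest amounts. The leaving group carries two hydrogen-bond acceptors and the entering phenyl none, so a rise beyond the scatter is expected, likely larger than the measured steps. Compound 4 is therefore estimated at 3.2, within 2.6 to 3.8, which means an expected step of a number 1.20 log units higher from compound 3 to compound 4 (beyond the scatter).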

Compound 4, distribution coefficient: 3.3
Beside the measured number, compound 4's estimate is 0.10 log units below it, and the stated range covers the measured number.
By their numbers in this assay, from the lowest: compound 1; then compounds 2 and 3 (each within the scatter of the next); then compound 4.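

In this assay, phenyl in place of (pyridin-3-yl)carbonyl on a nitrogen on an aromatic ring gives a number 1.30 log units higher from compound 3 to compound 4 (beyond the scatter), a large step, whereas the steps among compound 1, compound 2 and compound 3 were modest at most. Anilino on the aromatic carbon also gives large steps against both rings with a 2-oxopyrrolidin-1-yl pattern, with a number 1.30 log units higher from compound 2 to compound 4 (beyond the scatter) for the 4,4-dimethyl-2-oxopyrrolidin-1-yl group and a number 2.00 log units higher from compound 1 to compound 4 (beyond the scatter) for the 2-oxopyrrolidin-1-yl group. Exchanging the group at this one place therefore moves the number much further than the first three compounds showed, and compound 4 now holds the highest number of the four, with its steps to all the others printed as beyond the scatter.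

Nothing measured here accounts for the size of this rise. The step to compound 4 takes away the carbonyl and the ring nitrogen together, which leaves open how much of the rise goes with each, a split that a benzoyl or a pyridin-3-yl group on that nitrogen would show.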